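Salicylanilide series: phenyl removal at a bromo-bearing core

The source may report more compounds than this note shows. Statements on the series, on what has been measured and on what is new or still open speak of the compounds shown alone.

Measured so far:
- compound 1, `N#Cc1ccc(NC(=O)c2ccc(-c3ccccc3)cc2O)cc1`: 410 nM
- compound 2, `N#Cc1ccc(NC(=O)c2ccccc2O)cc1`: 5370 nM
- compound 3, `N#Cc1ccc(NC(=O)c2cc(Br)c(-c3ccccc3)cc2O)cc1`: 850 nM

All three were run in a functional assay on KG-1 cells (Homo sapiens) for cytotoxicity, read by luminescence and CellTiter-Glo, with a stated time of 3 days; on this read-out lower numbers stand for stronger inhibition and higher numbers for weaker inhibition. Compound 1 has the lowest number of the three; compound 3 sits next, and compound 2 highest. The step of a 2.1-fold higher number from compound 1 to compound 3 (0.32 log units; beyond the scatter) is modest, the step of a 13-fold higher number from compound 1 to compound 2 (1.12 log units; beyond the scatter) is large.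

Compound 4, `N#Cc1ccc(NC(=O)c2cc(Br)ccc2O)cc1`, has not been measured in this assay. It relates to compound 3 as compound 2 relates to compound 1. The two cores differ by bromo in place of hydrogen on an aromatic carbon. The change from compound 1 to compound 2 is hydrogen in place of phenyl on an aromatic carbon; the change from compound 3 to compound 4 is hydrogen in place of phenyl on an aromatic carbon. These are the same kind of change, not the same: in compound 3 the place is also ortho to a bromo group, which it is not in compound 1. The change occurs twice among the compounds shown, once with a measured outcome.

In this assay, going by the values given here, the step from compound 3 to compound 4 is expected to be large, estimated at an 11-fold higher number from compound 3 to compound 4 (1.02 log units; beyond the scatter), because the only measured example of this kind of change gave a 13-fold higher number from compound 1 to compound 2 (1.12 log units; beyond the scatter). Nothing here shows how the bromo group next to the place alters that, so the range is set wide. For compound 4 the estimate is 9000 nM, with a range from 3000 nM to 30000 nM.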

Compound 4, half-maximal inhibitory concentration: 1290 nM
Beside the measured number, compound 4's estimate is 7.0-fold (0.84 log units) above it; the measured number lies below the stated range.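

In this assay hydrogen in place of phenyl gives a 1.5-fold higher number from compound 3 to compound 4 (0.18 log units; within the scatter), so with bromo present this change leaves no step beyond the scatter, and it does not carry over from the core of compound 1: the same change on two cores in this assay, a 13-fold higher number (1.12 log units; beyond the scatter) from compound 1 to compound 2 and a 1.5-fold higher number (0.18 log units; within the scatter) from compound 3 to compound 4, 8.6-fold (0.94 log units) apart, beyond the scatter of two such steps. The bromo change does not carry over either, giving a 4.2-fold lower number from compound 2 to compound 4 (0.62 log units; beyond the scatter) where phenyl is absent, while with phenyl present the step runs the other way: the same change on two cores in this assay, a 2.1-fold higher number (0.32 log units; beyond the scatter) from compound 1 to compound 3 and a 4.2-fold lower number (0.62 log units; beyond the scatter) from compound 2 to compound 4, 8.6-fold (0.94 log units) apart, beyond the scatter of two such steps. These four compounds therefore show that a step measured on one core did not transfer to the other and that the phenyl and bromo changes do not add up independently, but they form only one such set and do not show why the steps differ or whether the same holds for other groups.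

On these data alone, it remains open whether a methyl group, a methoxy group or an amine in place of phenyl would follow the compound 1 to compound 2 pattern or the compound 3 to compound 4 pattern. As far as these compounds go, it also remains open whether chloro or a carboxylic acid in place of bromo would alter the phenyl step as bromo does here.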